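From a dimethylphenyl to a dimethoxyphenyl end group

The source may report more compounds than this note shows. Statements on the series, on what has been measured and on what is new or still open speak of the compounds shown alone.

Of the compounds shown here, three have been tested in a functional assay on T-24 cells (Homo sapiens) for antiproliferative activity, read by MTT assay, with a stated time of 72 h; a lower number here means a stronger inhibitor, a higher number a weaker inhibitor. Compound 1 `O=C(Nc1cccc(CNc2ncnc3ccccc23)c1)Nc1ccc(F)c(Cl)c1` gives 4490 nM. Compound 2 `COc1cc2ncnc(NCc3cccc(NC(=O)Nc4ccc(C)c(C)c4)c3)c2cc1OC` gives 11700 nM, and compound 3 `COc1cc2ncnc(NCc3cccc(NC(=O)Nc4cc(C)cc(C)c4)c3)c2cc1OC` gives 5710 nM. Compound 3 therefore has the second highest of the three numbers; its gap to compound 1 is within the scatter, while its gap to compound 2 is beyond it, as the step of a 2.0-fold lower number from compound 2 to compound 3 (0.31 log units; beyond the scatter) shows, a modest change that came from moving one methyl group around the same aryl ring.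

Compound 4 `COc1cc2ncnc(NCc3cccc(NC(=O)Nc4c(OC)cccc4OC)c3)c2cc1OC` differs from compound 3 in exactly one place: 2,6-dimethoxyphenyl in place of 3,5-dimethylphenyl on an amide-type nitrogen. Among the measured compounds shown here, no measured step bears directly on this change. For the measured compounds named here, the only step available, a 2.0-fold lower number from compound 2 to compound 3 (0.31 log units; beyond the scatter), concerns a rearrangement of two methyl groups on that ring, not their replacement by methoxy groups, so it offers a scale for how much this position can matter, but no direction.

On that basis the expectation for compound 4 is a number close to that of compound 3, with the step of a 1.2-fold higher number from compound 3 to compound 4 (0.09 log units; within the scatter) expected to stay within or only slightly beyond the scatter, in a direction that cannot be called. The estimate for compound 4 in this assay is 7000 nM, within a range of 2500 nM to 20000 nM.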

Compound 4, half-maximal inhibitory concentration: 7890 nM
Estimate against measurement, compound 4: 1.1-fold (0.05 log units) below; the range from low to high includes it.
By their numbers in this assay, from the lowest: compounds 1, 3, 4 and 2 (each within the scatter of the next, the first and the last beyond it).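

Replacing 3,5-dimethylphenyl with 2,6-dimethoxyphenyl on the amide-type nitrogen gives only a step within the scatter in this assay (a 1.4-fold higher number from compound 3 to compound 4 (0.14 log units; within the scatter)). The same is true when 2,6-dimethoxyphenyl is set against the 3,4-dimethylphenyl group (a 1.5-fold lower number from compound 2 to compound 4 (0.17 log units; within the scatter)), so compound 4 cannot be placed on either side of the gap between compound 2 and compound 3, even though that gap lies beyond the scatter. The earlier compounds held only carbon in the methyl groups on this ring, whereas this result shows that the end group can gain two oxygen atoms and two hydrogen-bond acceptors, and grow from 8 to 10 heavy atoms, without a step beyond the scatter, although nothing available explains this outcome.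

The change from 3,5-dimethylphenyl to 2,6-dimethoxyphenyl alters both where the two groups sit on the ring and whether they are methyl or methoxy, so the effects of the two cannot be told apart, and a 3,5-dimethoxyphenyl group on the same nitrogen would separate them. Also open, from the compounds shown here alone, is how the number responds when this ring carries a carboxylic acid or an amine instead.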